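Swapping benzyloxy for propyl on a carbonyl carbon

The source may hold more compounds than are shown below. What is called first, only, known or untested is meant among the compounds shown, and "the series" means these compounds.

Measured in a functional assay on HCT-116 cells (Homo sapiens) for inhibition, read by MTT assay, with a stated time of 96 h; on this read-out higher numbers stand for weaker inhibition of growth and lower numbers for stronger inhibition of growth:

Compound 1 `O=C(NCCCCCCSSCCCCCCNC(=O)c1cc(-c2ccncc2)n[nH]1)c1cc(-c2ccncc2)n[nH]1` gives 8930 nM
Compound 2 `O=C(OCc1ccccc1)SCCCCCCNC(=O)c1cc(-c2ccncc2)n[nH]1` gives 18200 nM

Compound 2 (18200 nM) holds the higher of the two numbers, so it is the weaker inhibitor of growth. Compound 1 lies lower, by a gap just beyond the usual scatter.

Compound 3 `CCCC(=O)SCCCCCCNC(=O)c1cc(-c2ccncc2)n[nH]1` has not yet been measured. It has propyl in place of benzyloxy on a carbonyl carbon, and the rest of compound 2 stays unchanged. Among the measured compounds shown here, no measured pair shows this swap, so the data give no direct guide to its effect in this assay. A small shift towards a lower number is expected, probably no larger than the scatter. The estimated step runs a 1.8-fold lower number from compound 2 to compound 3 (0.26 log units; within the scatter). Compound 3 is estimated at 10000 nM (range 3500 nM to 25000 nM).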

Compound 3, concentration for 50% growth inhibition: 23500 nM
The estimate for compound 3 lay 2.4-fold (0.37 log units) below the measured number; the measured number falls inside the stated range.
By their numbers in this assay, from the lowest: compound 1; then compounds 2 and 3 (each within the scatter of the next).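

In this assay the swap of propyl for benzyloxy on a carbonyl carbon gives a 1.3-fold higher number from compound 2 to compound 3 (0.11 log units; within the scatter) and so separates the two compounds by no more than repeat measurements of one compound might. Among the compounds shown here, the six-membered aromatic ring and the oxygen of benzyloxy can therefore both go from this place without a change in the number that can be told from scatter, which the earlier compounds could not show because neither carried propyl here. Nothing measured on these compounds explains this result.

Whether this carbonyl carbon would accept any group with the same lack of effect stays open, since only benzyloxy and propyl are shown on it. An amine, a carboxylic acid or a longer chain at this place could still move the number beyond the scatter.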